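Ring at the chain end: compound 3 to compound 4

A few compounds are considered here, and "the series" means these few. Any claim that something is new, unique, unknown or untested is made for them only; others in the source may bear on it.

Compound 1 `O=C(O)c1ccccc1-c1ccc(CCc2ncc(CC3CCCC3)[nH]2)cc1` gives 7.9 nM in an in vitro functional assay on cells for agonist activity at Bombesin receptor subtype-3 (Mus musculus), read by luminescence and calcium flux; a higher number here means that more compound is needed for the effect, a lower number that less compound is needed.
Compound 2 `N#Cc1ccc(Cc2cnc(CCc3ccc(-c4ccccc4C(=O)O)cc3)[nH]2)cc1` gives 723 nM in this assay.
Compound 3 `CCCCc1cnc(CCc2ccc(-c3ccccc3C(=O)O)cc2)[nH]1` gives 93 nM in this assay.

Compound 3 stands second highest of the three numbers; its nearest neighbour is compound 2 (a 7.8-fold lower number from compound 2 to compound 3 (0.89 log units; beyond the scatter)), its furthest compound 1 (a 12-fold higher number from compound 1 to compound 3 (1.07 log units; beyond the scatter)). Compound 4 `O=C(O)c1ccccc1-c1ccc(CCc2ncc(CCC3CCCCC3)[nH]2)cc1` differs from compound 3 by cyclohexyl in place of ethyl on a saturated chain carbon, two bonds along the chain from an aromatic carbon. Going by the values given here, the step that bears on it is the one between compound 1 and compound 3, where a saturated ring gave way to an open chain and the number rose sharply (a 12-fold higher number from compound 1 to compound 3 (1.07 log units; beyond the scatter)). Compound 4 brings a saturated ring back, though one bond further out, so a lower number than compound 3 is expected, likely a modest step (a 4.7-fold lower number from compound 3 to compound 4 (0.67 log units; beyond the scatter)). Compound 4 is estimated at 20 nM, between 5 nM and 80 nM.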

Compound 4, half-maximal effective concentration: 33 nM
The estimate for compound 4 lay 1.7-fold (0.22 log units) below the measured number; the range from low to high includes it.
By their numbers in this assay, from the lowest: compound 1; then compound 4; then compound 3; then compound 2.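

A saturated ring at the chain end pays off even when it sits further out, with cyclohexyl in place of ethyl giving a 2.8-fold lower number from compound 3 to compound 4 (0.45 log units; beyond the scatter). The cyclohexylmethyl group also far outdoes the 4-cyanophenyl end, with a 22-fold lower number from compound 2 to compound 4 (1.34 log units; beyond the scatter), yet it does not match the cyclopentyl end of the best compound, with a 4.2-fold higher number from compound 1 to compound 4 (0.62 log units; beyond the scatter). No evidence at hand gives a reason for these shifts. That last step changes both ring size and chain length, so the two effects remain unseparated. Going by these compounds, how an amine or a hydroxyl group on the ring would fare also stays open.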